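Anilino replacement on the shared core: notes toward compound 4

This account rests on a few compounds, and the source may have more. Where it says the series, first, only, none or still open, it means among the compounds named here.

Measured so far in an assay on mitochondria from L6 cells (Rattus norvegicus) for activation, with a stated time of 90 min; a higher number here means that more compound is needed for the effect, a lower number that less compound is needed:
compound 1, `Fc1cccc(Nc2nc3nonc3nc2Nc2ccccc2F)c1`, gives 190 nM
compound 2, `CCOc1ccccc1Nc1nc2nonc2nc1Nc1ccccc1F`, gives 5600 nM
compound 3, `CCOc1ccc(Nc2nc3nonc3nc2Nc2ccccc2F)cc1`, gives 3800 nM

Compound 3 stands second highest of the three numbers; its nearest neighbour is compound 2, separated by a 1.5-fold lower number from compound 2 to compound 3 (0.17 log units; within the scatter), a gap within the scatter, while compound 1 lies far below it, as a 20-fold higher number from compound 1 to compound 3 (1.30 log units; beyond the scatter) shows.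

Compound 4, `Oc1ccc(F)c(Nc2nc3nonc3nc2Nc2ccccc2F)c1`, is not yet measured. Its change from compound 3: 2-fluoro-5-hydroxyphenyl in place of 4-ethoxyphenyl on a nitrogen on an aromatic ring.

Among the measured compounds shown here, two measured steps bear on this. The group entering resembles the fluorophenyl of compound 1 more than the ethoxyphenyls of compound 2 and compound 3, and both a 29-fold higher number from compound 1 to compound 2 (1.47 log units; beyond the scatter) and a 20-fold higher number from compound 1 to compound 3 (1.30 log units; beyond the scatter) were large. Reversing that direction suggests a substantial drop in this assay, but the hydroxyl has no precedent here, so the drop is expected to fall short of the full return to compound 1. Compound 4 is therefore expected at 700 nM, between 150 nM and 3500 nM, an expected step of a 5.4-fold lower number from compound 3 to compound 4 (0.73 log units; beyond the scatter).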

Compound 4, half-maximal effective concentration: 30000 nM
Compound 4: middle estimate off by 43-fold (1.63 log units), on the low side; the measured number lies above the stated range.
By their numbers in this assay, from the lowest: compound 1; then compounds 3 and 2 (each within the scatter of the next); then compound 4.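

In this assay, this position proves less forgiving than the resemblance to compound 1 suggested: with a 160-fold higher number from compound 1 to compound 4 (2.20 log units; beyond the scatter) as the largest step in the series, sharing a fluorine-bearing phenyl with compound 1 does not carry over its low number. The 2-fluoro-5-hydroxyphenyl group also falls behind both ethoxyphenyl groups, with a 7.9-fold higher number from compound 3 to compound 4 (0.90 log units; beyond the scatter) and a 5.4-fold higher number from compound 2 to compound 4 (0.73 log units; beyond the scatter) as the steps, so compound 4 goes against any reading of fluorophenyl as favourable and ethoxyphenyl as unfavourable here. Relative to 4-ethoxyphenyl, the entering group has 1 hydrogen-bond donor instead of 0 and is otherwise close in size.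

The compounds shown do not separate the hydroxyl from the placing of the fluorine, and they leave open how a methoxy group or an amine in place of that hydroxyl would read. No measurement here bears on what lies behind this rise.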